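This account rests on a few compounds, and the source may have more. Where it says the series, first, only, none or still open, it means among the compounds named here.

In an ADME assay on CHO cells (Cricetulus griseus) for cytotoxicity, read by MTT assay (a lower number here means that less compound is tolerated, a higher number that more compound is tolerated), compound 3 (`CN1CCN(CC2CCN(c3nccc4[nH]c(-c5ccc(F)c(Cl)c5)nc34)CC2)CC1`) gives 850 nM. Compound 2 (`CN1CCN(CC2CCN(c3nccc4[nH]c(-c5cccc(OC(F)(F)F)c5)nc34)CC2)CC1`) gives 950 nM, and these two values lie within the scatter of each other. Compound 1 (`Fc1ccc(-c2nc3c(N4CCCN(CC5CC5)CC4)nccc3[nH]2)cc1F`) stands well apart at 17000 nM, a clearly higher number than compound 3 shows, but the two differ in more than one place, so this gap isolates no single change.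

Compound 4 (`CN1CCN(CC2CCN(c3nccc4[nH]c(-c5cccc(C(=O)N(C)C)c5)nc34)CC2)CC1`) has not yet been measured. It differs from compound 3 in one group: 3-(dimethylcarbamoyl)phenyl in place of 3-chloro-4-fluorophenyl on an aromatic carbon. In words, 3-(dimethylcarbamoyl)phenyl stands in place of 3-chloro-4-fluorophenyl, on an aromatic carbon between two ring nitrogen atoms.

For the measured compounds named here, only one measured step bears on this place: a 1.1-fold lower number from compound 2 to compound 3 (0.05 log units; within the scatter). That exchange of one substituted phenyl for another stayed within the scatter, which suggests little response here, yet neither group in it is a 3-(dimethylcarbamoyl)phenyl, so the step is only a weak guide. Compound 1, at 17000 nM, shows that much higher numbers do occur among these compounds, though not through this change. A modest move to a higher number is therefore expected, with the estimated size a 2.4-fold higher number from compound 3 to compound 4 (0.37 log units; beyond the scatter). For compound 4 the expected value is 2000 nM, with an estimated range from 800 nM to 7000 nM.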

Compound 4, half-maximal cytotoxic concentration: > 50000 nM
Compound 4 ended at the assay's limit; the forecaster's own chance of this, stated with the estimate: 5%; at least 25-fold (1.39 log units) between middle value and limit.
By their numbers in this assay, from the lowest: compounds 3 and 2 (each within the scatter of the next); then compound 1. At a limit, above all of these: compound 4.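

In this assay compound 4 gives > 50000 nM, which is a limit of the assay and not a number, and it alone among the compounds shown stands there: the limit of > 50000 nM in this assay, at which 1 of the 4 values shown sits.

The earlier exchange of one substituted phenyl for another stayed within the scatter, a 1.1-fold lower number from compound 2 to compound 3 (0.05 log units; within the scatter), but this position, on an aromatic carbon between two ring nitrogen atoms, clearly can respond, with an at least 58-fold higher number from compound 3 to compound 4 (1.76 log units; beyond the scatter) when 3-(dimethylcarbamoyl)phenyl replaces 3-chloro-4-fluorophenyl, and an at least 52-fold higher number from compound 2 to compound 4 (1.72 log units; beyond the scatter) when dimethylcarbamoyl replaces trifluoromethoxy. Both steps are large and run in the same direction from two different starting groups, so the change follows the entering group rather than one particular group leaving. The entering group also brings a hydrogen-bond acceptor that 3-chloro-4-fluorophenyl does not have, though nothing shown ties the step to that count.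

The compounds shown leave open how far the true number of compound 4 lies past the limit, so the size of both steps has only a lower bound. They also leave open whether the dimethylamide itself is what matters, since a primary amide, a carboxylic acid or an aminomethyl group on the same phenyl ring could show whether other groups give the same result.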